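This account rests on a few compounds, and the source may have more. Where it says the series, first, only, none or still open, it means among the compounds named here.

Measured so far:
compound 1, `O=c1[nH]c(=O)n([C@H]2C[C@H](O)[C@@H](CO)O2)cc1C#CI`: 760 nM
compound 2, `C[Si](C)(C)C#Cc1cn([C@H]2C[C@H](O)[C@@H](CO)O2)c(=O)[nH]c1=O`: 180 nM
compound 3, `C#Cc1cn([C@@H]2O[C@H](CO)[C@@H](O)[C@@H]2O)c(=O)[nH]c1=O`: > 200000 nM

In an ADME assay on HEL cells (Homo sapiens) for cytotoxicity (a higher number here means that more compound is tolerated, a lower number that less compound is tolerated), compound 1 gives 760 nM and compound 2 gives 180 nM. Compound 3 stands apart: in this assay compound 3 gives > 200000 nM, which is a limit of the assay and not a number, namely (the limit of > 200000 nM in this assay, at which 1 of the 3 values shown sits). Compound 4, `C[Si](C)(C)C#Cc1cn([C@@H]2O[C@H](CO)[C@@H](O)[C@@H]2O)c(=O)[nH]c1=O`, has not been measured. It differs from compound 3 by a group of 4 heavy atoms (3 carbon, 1 silicon; no ring) in place of a hydrogen atom, on a triple-bonded carbon. Within the data shown here, the only measured step that bears on this change is a 4.2-fold lower number from compound 1 to compound 2 (0.63 log units; beyond the scatter), where the same group entered on the same kind of carbon but took the place of iodine rather than of a hydrogen atom. As compound 3 sits at the limit, a step of that size downward would still leave compound 4 at a high number, and a second limit is quite possible. For compound 4 in this assay the estimate is 100000 nM, with a range from 20000 nM to 200000 nM. The step expected is an at least 2.0-fold lower number from compound 3 to compound 4 (0.30 log units; that floor lies within the scatter).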

Compound 4, half-maximal cytotoxic concentration: 127000 nM
The estimate for compound 4 lay 1.3-fold (0.10 log units) below the measured number; measured number inside the range.
By their numbers in this assay, from the lowest: compound 2; then compound 1; then compound 4. At a limit, above all of these: compound 3.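

In this assay, the silicon-bearing group on the triple-bonded carbon does not by itself bring a low number: with that group held fixed, hydroxy in place of hydrogen on a saturated ring carbon gives a 710-fold higher number from compound 2 to compound 4 (2.85 log units; beyond the scatter). Putting the same group in place of a hydrogen atom on the triple-bonded carbon gives an at least 1.5-fold lower number from compound 3 to compound 4 (0.19 log units; that floor lies within the scatter), so this change shows no clear effect on the core of compound 3. Compound 3 gives > 200000 nM, which is a limit of the assay and not a number, so the true size of this step stays unknown: the limit of > 200000 nM in this assay, at which 1 of the 4 values shown sits.

The compounds shown leave open whether the hydroxy step would be as large with iodine on the triple-bonded carbon. They also leave open how a longer carbon chain at that carbon, or an amine in place of the hydroxy, would compare.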